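Bromo for methoxy: the expected step from compound 2

The source may hold more compounds than are shown below. What is called first, only, known or untested is meant among the compounds shown, and "the series" means these compounds.

Of the compounds shown here, three have been read in a functional assay on the whole organism for positive allosteric modulation, with Mus musculus as the target; on this read-out higher numbers stand for an effect only at larger amounts of compound and lower numbers for an effect already at smaller amounts. Compound 1 `CCC(=O)N(c1ccccc1C)C1CCCC1N(C)C` gives > 50 mg/kg, which is a limit of the assay and not a number. Compound 2 `CCC(=O)N(c1cccc(OC)c1)C1CCCC1N(C)C` gives 4 mg/kg, the lower of the two actual numbers, and compound 3 `CCC(=O)N(c1ccc(OC)c(OC)c1)C1CCCC1N(C)C` gives 10 mg/kg.

The change under study turns compound 2 into compound 4 `CCC(=O)N(c1cccc(Br)c1)C1CCCC1N(C)C`: bromo in place of methoxy on an aromatic carbon. It is bromo in place of methoxy on an aromatic carbon, meta to a large group.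

Within the data shown here, only one measured step bears on this, and only indirectly: a 2.5-fold higher number from compound 2 to compound 3 (0.40 log units; beyond the scatter), a modest step beyond the scatter, with methoxy in place of hydrogen on an aromatic carbon. Among the measured compounds shown here, no measured compound carries bromo, and no measured step removes the methoxy of compound 2. The size of that one step therefore serves as a rough guide, and the data give no firm direction. A slight lean towards a higher number rests only on compound 2 holding the lowest number, 4 mg/kg. The expected change is small, a 1.5-fold higher number from compound 2 to compound 4 (0.18 log units; within the scatter), and no step beyond the scatter is expected. For compound 4 the estimated value is 6 mg/kg, with an expected range of 2 mg/kg to 20 mg/kg.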

Compound 4, dose for half-maximal effect: 2 mg/kg
Estimate against measurement, compound 4: 3.0-fold (0.48 log units) above; measured number inside the range.
By their numbers in this assay, from the lowest: compounds 4 and 2 (each within the scatter of the next); then compound 3. At a limit, above all of these: compound 1.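

In this assay, the exchange at this position gives a 2.0-fold lower number from compound 2 to compound 4 (0.30 log units; within the scatter), so a number at the low end of the series does not depend on the methoxy of compound 2, and bromo on this aromatic carbon, meta to a large group, serves as well. Among these compounds, the earlier compounds could not show this: their one readable step, a 2.5-fold higher number from compound 2 to compound 3 (0.40 log units; beyond the scatter), adds a second methoxy and leaves the first in place, whereas here the methoxy itself leaves, with its hydrogen-bond acceptor, and bromo, which has none, enters without a step beyond the scatter. No measurement shown bears on why these two groups read alike.

As far as these compounds go, whether this position accepts other groups, such as chloro, an amine or a carboxylic acid, remains open, as does the effect of bromo on other carbons of the ring. From the compounds shown here alone, compound 1 gives > 50 mg/kg, which is a limit of the assay, and steps to it cannot be read, so what a methyl group does on this ring also remains open.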